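The source may report more compounds than this note shows. Statements on the series, on what has been measured and on what is new or still open speak of the compounds shown alone.

Three acids of this series have numbers in an in vitro functional assay on 1321-N1 cells for agonist activity at Free fatty acid receptor 1 (Homo sapiens), read by fluorescence, spectrophotometry and calcium flux; a higher number here means that more compound is needed for the effect, a lower number that less compound is needed. Compound 1 `O=C(O)CCc1ccc(C#Cc2ccnc(F)c2)cc1` gives 513 nM, compound 2 `O=C(O)CCc1ccc(C#Cc2ccccn2)cc1` gives 13200 nM, and compound 3 `Cc1c(C#Cc2ccc(CCC(=O)O)cc2)ccnc1F` gives 120 nM. How the cores of compound 1 and compound 2 differ is not broken down here. Compound 3 arises from compound 1 by methyl in place of hydrogen on an aromatic carbon, a change worth a 4.3-fold lower number from compound 1 to compound 3 (0.63 log units; beyond the scatter). Compound 4 `Cc1cccc(C#Cc2ccc(CCC(=O)O)cc2)n1` arises from compound 2 by the same kind of change, (methyl in place of hydrogen on an aromatic carbon); the surroundings differ, the methyl here sitting next to the ring nitrogen and meta to a large group rather than ortho to a fluoro group, ortho to a large group and two atoms from the ring nitrogen. Going by the values given here, a step of similar size is expected, a 3.3-fold lower number from compound 2 to compound 4 (0.52 log units; beyond the scatter), resting on the single precedent a 4.3-fold lower number from compound 1 to compound 3 (0.63 log units; beyond the scatter). Compound 4 is therefore estimated at 4000 nM, within 1500 nM to 12000 nM.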

Compound 4, half-maximal effective concentration: 6170 nM
Compound 4: middle estimate off by 1.5-fold (0.19 log units), on the low side; low and high end bracket the measured number.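

In this assay, methyl in place of hydrogen on an aromatic carbon again gives a lower number, a 2.1-fold lower number from compound 2 to compound 4 (0.33 log units; beyond the scatter), so the change points the same way on both cores. The two steps do not differ in size beyond the scatter: the same change on two cores in this assay, a 4.3-fold lower number (0.63 log units; beyond the scatter) from compound 1 to compound 3 and a 2.1-fold lower number (0.33 log units; beyond the scatter) from compound 2 to compound 4, 2.0-fold (0.30 log units) apart, within the scatter of two such steps. Going by these compounds alone, this rests on only two pairs with the methyl in different surroundings, so it shows neither that the step holds on further cores nor how much the surroundings of the methyl contribute.

Open, going by these compounds, is whether an ethyl, a chloro or a methoxy group on the same aromatic carbon would give a step like that of methyl. Also open, on these data alone, is how either step would fare with a longer chain carrying the carboxylic acid.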